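From Azetidinyl to Dimethylamino on the Shared Core

A few compounds are considered here, and "the series" means these few. Any claim that something is new, unique, unknown or untested is made for them only; others in the source may bear on it.

Compound 1 `CCCc1cc(N)c2cc(NC(=O)c3ccc(-c4ccc(Cl)cc4)cc3)ccc2n1`: 75 nM
Compound 2 `CCCc1cc(N2CCC2)c2cc(NC(=O)/C=C/c3ccc(C(F)(F)F)cc3)ccc2n1`: 2500 nM
Compound 3 `CCCc1cc(N)c2cc(NC(=O)/C=C/c3ccc(SC)cc3)ccc2n1`: 71 nM

Three compounds share a core and differ in the amine on it and in the amide side chain. In a functional assay on HEK293 cells for activation of melanin-concentrating hormone receptor 1 (Homo sapiens), read by inositol phosphate accumulation (on this read-out lower numbers stand for an effect already at smaller amounts and higher numbers for an effect only at larger amounts of compound), compound 1 gives 75 nM and compound 3 gives 71 nM; the two carry a plain amino group and their numbers lie within the scatter of one another. Compound 2, with an azetidin-1-yl group and a trifluoromethyl-bearing cinnamamide, gives 2500 nM, the highest number of the three and beyond the scatter from both others.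

Compound 4 `CCCc1cc(N(C)C)c2cc(NC(=O)/C=C/c3ccc(C(F)(F)F)cc3)ccc2n1` has not been measured. It differs from compound 2 in one place: dimethylamino in place of azetidin-1-yl on an aromatic carbon. Within the data shown here, no directly comparable step between measured compounds exists; the only measured neighbours change two things at once, so they set no size for this change. Since compound 2 gives 2500 nM, compound 4 is expected to stay near it, with a step from compound 2 to compound 4 of a 1.7-fold lower number from compound 2 to compound 4 (0.22 log units; within the scatter), not clearly beyond the scatter, so that compound 4 is estimated at 1500 nM within 400 nM to 6000 nM.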

Compound 4, half-maximal effective concentration: 300 nM
For compound 4 the middle estimate is 5.0-fold (0.70 log units) above the measured one; measured number outside the range, below it.
By their numbers in this assay, from the lowest: compounds 3 and 1 (each within the scatter of the next); then compound 4; then compound 2.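

Replacing azetidin-1-yl with dimethylamino on the aromatic carbon opposite the ring nitrogen gives, in this assay, an 8.3-fold lower number from compound 2 to compound 4 (0.92 log units; beyond the scatter), the first change in a single place among these compounds. The earlier numbers could not separate the amine from the side chain, whereas here the trifluoromethyl-bearing cinnamamide stays fixed, so the group at this position alone moves the number beyond the scatter, even though the hydrogen-bond donor and acceptor counts of the two groups are the same. No measurement at hand gives a reason for the size of this step.

Still open, as far as these compounds go, is how a pyrrolidin-1-yl or diethylamino group at this carbon would compare, and whether a plain amino group on the same cinnamamide would reach the numbers of compound 1 and compound 3. From the compounds shown here alone, it is also open whether the same exchange would give a step of similar size with the methylthio-bearing side chain of compound 3.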